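Methanesulfonamido for Chloro on a Benzylamine Side Chain

A few compounds are considered here, and "the series" means these few. Any claim that something is new, unique, unknown or untested is made for them only; others in the source may bear on it.

Measured compounds:
compound 1, `CNc1nc(NCC(C)(C)C)cc(-c2ccccn2)n1`, 73 nM
compound 2, `CNc1nc(NCc2ccc(Cl)cc2)cc(-c2ccccn2)n1`, 15 nM

Of the compounds shown here, two sharing one core have been measured in a functional assay on HEK293 cells for agonist activity at G-protein coupled receptor 39 (Homo sapiens), read by inositol phosphate accumulation; on this read-out lower numbers stand for an effect already at smaller amounts and higher numbers for an effect only at larger amounts of compound. Compound 1 carries a neopentyl chain on the ring nitrogen and gives 73 nM. Going by the values given here, compound 2 instead carries a 4-chlorobenzyl chain and gives 15 nM, the lower of the two numbers; the single step, a 4.9-fold lower number from compound 1 to compound 2 (0.69 log units; beyond the scatter), is the only one recorded.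

Compound 3, `CNc1nc(NCc2ccc(NS(C)(=O)=O)cc2)cc(-c2ccccn2)n1`, is not yet measured. Its difference from compound 2 is methanesulfonamido in place of chloro on an aromatic carbon. Among the compounds with values here, no measured step touches the substituent on that aromatic ring: the one recorded step exchanges the whole tert-butyl for 4-chlorophenyl, so it says nothing about swapping chloro for methanesulfonamido while the phenyl stays. The expectation can therefore rest only on compound 2 itself, with wide uncertainty in either direction. Compound 3 is expected to give about 40 nM, with a range from 8 nM to 200 nM, which would mean an estimated 2.7-fold higher number from compound 2 to compound 3 (0.43 log units; beyond the scatter).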

Compound 3, half-maximal effective concentration: 3 nM
Beside the measured number, compound 3's estimate is 13-fold (1.12 log units) above it, and the stated range ends above it.
By their numbers in this assay, from the lowest: compound 3; then compound 2; then compound 1.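

With the phenyl ring kept and only its substituent exchanged, the change from chloro to methanesulfonamido gives a 5.0-fold lower number from compound 2 to compound 3 (0.70 log units; beyond the scatter) in this assay, so the number responds to the group on this aromatic carbon, para to a large group, and not only to the exchange of the whole tert-butyl for 4-chlorophenyl seen earlier. The position therefore tolerates far more than a single chlorine: a group of 5 heavy atoms, with 1 hydrogen-bond donor and 2 hydrogen-bond acceptors where chloro has none, enters and the number falls instead of rising. Nothing available explains why this exchange lowers the number.

The compounds shown do not separate the contributions of the parts of the new group, so it stays open whether an acetamido group, a methanesulfonyl group without the nitrogen, or a methanesulfonamido group with a methyl on that nitrogen would give a similar number. As far as these compounds go, it also stays open how a carboxylic acid or a primary amine on the same carbon would compare, and whether the methanesulfonamido group would have the same effect on another carbon of that ring.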